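Swapping Amino for Chloro on the Benzyl Ring

The source may report more compounds than this note shows. Statements on the series, on what has been measured and on what is new or still open speak of the compounds shown alone.

Compound 1 `C/C=C/C(=O)N(Cc1ccc(OC)c(N)c1)c1cc(OC)c(OC)c(OC)c1` is tested in a functional assay on KYSE-450 cells (Homo sapiens) for inhibition, read by MTT assay, with a stated time of 48 h (a lower number here means a stronger inhibitor, a higher number a weaker inhibitor), where it gives 310 nM. Among the measured compounds shown here, that is the higher of the two numbers known so far: compound 2 `CCC(=O)N(Cc1ccc(OC)c(O)c1)c1cc(OC)c(OC)c(OC)c1` gives 98 nM in this assay. Compound 3 `C/C=C/C(=O)N(Cc1ccc(OC)c(Cl)c1)c1cc(OC)c(OC)c(OC)c1` differs from compound 1 by one change, (chloro in place of amino on an aromatic carbon). For the measured compounds named here, no measured pair shows the effect of this exact swap, so the expectation rests on compound 1 alone. The step of a 1.0-fold lower number from compound 1 to compound 3 (0.01 log units; within the scatter) is expected to stay within the usual scatter, in no clear direction. Compound 3 is therefore estimated at 300 nM, with a likely range from 100 nM to 1000 nM.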

Compound 3, half-maximal inhibitory concentration: 10100 nM
For compound 3 the middle estimate is 34-fold (1.53 log units) below the measured one; measured number above the stated range.
By their numbers in this assay, from the lowest: compound 2; then compound 1; then compound 3.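

In this assay, this aromatic carbon, ortho to a methoxy group, proves highly sensitive to what it carries: replacing amino with chloro gives a 33-fold higher number from compound 1 to compound 3 (1.51 log units; beyond the scatter), so compound 3 is a much weaker inhibitor. Amino counts one hydrogen-bond donor and one acceptor and chloro counts none, but this difference alone does not establish what drives the loss. No measurement available here accounts for the drop.

From the compounds shown here alone, whether a fluoro, methyl or dimethylamino group on this carbon would read closer to compound 1 or to compound 3 remains open.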